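The source may report more compounds than this note shows. Statements on the series, on what has been measured and on what is new or still open speak of the compounds shown alone.

Compounds measured so far in a functional assay on MGC-803 cells (Homo sapiens) for inhibition, read by MTT assay; on this read-out lower numbers stand for stronger inhibition and higher numbers for weaker inhibition:

Compound 1 `Cc1c(C(=O)N/N=C\c2ccccc2O)oc2cccc(O)c12`: 10600 nM
Compound 2 `Cc1c(C(=O)N/N=C\c2c(O)cccc2F)oc2cccc(O)c12`: 10800 nM
Compound 3 `Cc1ccc(O)c(/C=N\NC(=O)c2oc3cccc(O)c3c2C)c1`: 5990 nM

Compound 2 gives the highest of the three numbers in this assay, yet neither of its neighbours is separated from it by more than the scatter: the step of a 1.0-fold higher number from compound 1 to compound 2 (0.01 log units; within the scatter) is essentially flat, and the step of a 1.8-fold lower number from compound 2 to compound 3 (0.26 log units; within the scatter) stays inside the usual variation as well. Going by the values given here, the only other comparison, a 1.8-fold lower number from compound 1 to compound 3 (0.25 log units; within the scatter), likewise falls short of a real change. The series therefore shows three compounds that cannot be told apart on this read-out.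

Compound 4 `Cc1c(C(=O)N/N=C\c2ccc(O)cc2O)oc2cccc(O)c12` has not yet been measured. It differs from compound 2 in one place:

2,4-dihydroxyphenyl in place of 2-fluoro-6-hydroxyphenyl on a carbon with a double bond to nitrogen

The step bearing most directly on this change is a 1.8-fold lower number from compound 2 to compound 3 (0.26 log units; within the scatter), where the same 2-fluoro-6-hydroxyphenyl was exchanged for a differently substituted hydroxyphenyl group without a move beyond the scatter. The step of a 1.0-fold higher number from compound 1 to compound 2 (0.01 log units; within the scatter) shows that the fluoro itself makes no measurable difference. Nothing in the data suggests that adding a second hydroxy should behave otherwise, so no step beyond the scatter is expected in this assay, perhaps leaning slightly to a lower number.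

Compound 4 is therefore estimated at 8000 nM in this assay, within a range of 3000 nM to 22000 nM, which corresponds to an expected step of a 1.4-fold lower number from compound 2 to compound 4 (0.13 log units; within the scatter).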

Compound 4, half-maximal inhibitory concentration: 7330 nM
Compound 4: the middle estimate sits 1.1-fold (0.04 log units) above what was measured, within the range that was stated.
By their numbers in this assay, from the lowest: compounds 3, 4, 1 and 2 (each within the scatter of the next).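

In this assay the aromatic group on the carbon with a double bond to nitrogen accepts a further hydroxy without a change that can be read, as adding it to the group of compound 1 gives only a small step (a 1.4-fold lower number from compound 1 to compound 4 (0.16 log units; within the scatter)). The same holds when 2,4-dihydroxyphenyl, with 2 hydrogen-bond donors and 2 hydrogen-bond acceptors, replaces 2-fluoro-6-hydroxyphenyl, with 1 of each (a 1.5-fold lower number from compound 2 to compound 4 (0.17 log units; within the scatter)), and when it replaces 2-hydroxy-5-methylphenyl (a 1.2-fold higher number from compound 3 to compound 4 (0.09 log units; within the scatter)), so hydrogen, fluoro, methyl and a further hydroxy on this ring cannot be told apart on this read-out, and the four compounds form a flat stretch of the series. Nothing available gives a measured explanation for these small differences.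

The compounds shown leave open whether the hydroxy they all carry on this ring is needed at all, since an unsubstituted phenyl or a methoxy, amine or carboxylic acid in its place could show whether this position can move the number beyond the scatter. They also leave open whether changes to the shared core would matter more than those on this ring.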